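This account rests on a few compounds, and the source may have more. Where it says the series, first, only, none or still open, it means among the compounds named here.

Working notes on the series, read in a functional assay on SW-620 cells (Homo sapiens) for antiproliferative activity, read by MTT assay, with a stated time of 72 h; on this read-out higher numbers stand for weaker inhibition and lower numbers for stronger inhibition. Compound 1 `Oc1ccc2ccccc2c1/C=N/NC(=S)Nc1ccccc1` gives 300 nM. Compound 3 `CCN(CC)c1ccc(/C=N/NC(N)=S)c(O)c1` gives 3000 nM. Compound 2 `NC(=S)N/N=C/c1ccccc1O` gives > 5000 nM, which is a limit of the assay and not a number. Compound 2 therefore offers only a bound as the starting point, not a measured position.

Compound 4 `COc1cccc(/C=N/NC(N)=S)c1O` is compound 2 with methoxy in place of hydrogen on an aromatic carbon, ortho to a hydroxy group and meta to a group of 6 heavy atoms: methoxy in place of hydrogen on an aromatic carbon. For the measured compounds named here, the only measured step that bears on this change is an at least 1.6-fold lower number from compound 2 to compound 3 (0.22 log units; that floor lies within the scatter). That step brings in diethylamino, a different group from methoxy, and its floor lies within the scatter. It gives no firm size or direction for the new change. Compound 1 differs from compound 2 in more than one place and gives no guide to this single change.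

No step beyond the scatter is therefore expected, although any drift would be expected toward lower numbers. The expected change is a number no higher from compound 2 to compound 4 (the limit leaves the size open). For compound 4 the estimated value is 5000 nM, with an expected range of 1800 nM to 14000 nM.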

Compound 4, half-maximal inhibitory concentration: 500 nM
Estimate against measurement, compound 4: 10-fold (1.00 log units) above; measured number outside the range, below it.
By their numbers in this assay, from the lowest: compounds 1 and 4 (each within the scatter of the next); then compound 3. At a limit, above all of these: compound 2.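

In this assay, for the compounds shown here, methoxy on the aromatic carbon ortho to a hydroxy group and meta to a group of 6 heavy atoms gives an at least 10-fold lower number from compound 2 to compound 4 (1.00 log units; beyond the scatter), while the one earlier single change, diethylamino in place of hydrogen on an aromatic carbon, gives only an at least 1.6-fold lower number from compound 2 to compound 3 (0.22 log units; that floor lies within the scatter). This makes the methoxy change the only single change shown that stands beyond the scatter, and it does so with an entering group of 2 heavy atoms, no ring and no hydrogen-bond donor. Compound 2 gives > 5000 nM, which is a limit of the assay and not a number.

As far as these compounds go, the full size of the step stays open because its starting point is only a limit: the limit of > 5000 nM in this assay, at which 1 of the 4 values shown sits. How ethoxy or a carboxylic acid on this same aromatic carbon would read stays open, as does whether methoxy on another aromatic carbon of the shared core would give a step of similar size.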